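This account rests on a few compounds, and the source may have more. Where it says the series, first, only, none or still open, it means among the compounds named here.

Compound 1 `COc1cc(-c2cc(/C=C/C(=O)c3ccc(N)cc3)[nH]n2)cc(OC)c1OC`: -18%
Compound 2 `COc1ccc(C(=O)/C=C/c2cc(-c3cc(OC)c(OC)c(OC)c3)n[nH]2)cc1OC`: 2%

Both numbers come from a functional assay on SR cells (Homo sapiens) for cytotoxicity, read by sulforhodamine B assay, with a stated time of 48 h, tested at 10 uM; a lower number here means a stronger effect, a higher number a weaker effect of the compound at the concentration tested. Within the data shown here, compound 2 stands highest of the two measured numbers, and the one measured step, a number 20 percentage points higher from compound 1 to compound 2 (beyond the scatter), separates them. Compound 3 `COc1cc(C(=O)/C=C/c2cc(-c3cc(OC)c(OC)c(OC)c3)n[nH]2)cc(OC)c1OC` differs from compound 2 by methoxy in place of hydrogen on an aromatic carbon. That single measured step exchanged a whole aryl group on the carbonyl carbon, not a hydrogen for a methoxy, so it gives no direct guide to this change. From compound 2 to compound 3 the step is expected to stay within the scatter, a number 2 percentage points lower from compound 2 to compound 3 (within the scatter). Compound 3 is therefore estimated at 0%, in a range from -25% to 20%.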

Compound 3, a percentage reported as activity, at one concentration (the size of the read-out at that concentration, not a potency): 12%
Compound 3: middle estimate off by 12 percentage points, on the low side; the measured number falls inside the stated range.
By their numbers in this assay, from the lowest: compound 1; then compounds 2 and 3 (each within the scatter of the next).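

Adding methoxy on an aromatic carbon, ortho to a methoxy group and meta to a large group, gives a step in this assay of a number 10 percentage points higher from compound 2 to compound 3 (within the scatter). So at this position, the extra methoxy does not move the number beyond the scatter, a finding that the earlier whole-aryl exchange could not give. No measurement shown here explains this result.

The compounds shown leave open whether another group on this same carbon, such as an amine, a hydroxyl or an ethoxy chain, would shift the number beyond the scatter.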